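Compound 4 Expected from the Steps Around Compound 2

The source may hold more compounds than are shown below. What is called first, only, known or untested is meant among the compounds shown, and "the series" means these compounds.

In an ADME assay on WI-38 cells (Homo sapiens) for inhibition, read by MTT assay, with a stated time of 72 h (a higher number here means a weaker inhibitor, a lower number a stronger inhibitor), compound 1 `O=C(OC1(C(=O)Nc2ccc([N+](=O)[O-])cc2)CCCCC1)c1ccc(C(F)(F)F)cc1` gives 185 nM, compound 2 `COc1ccc(C(=O)OC2(C(=O)Nc3ccc([N+](=O)[O-])cc3)CCCCC2)cc1` gives 40 nM, and compound 3 `O=C(OC1(C(=O)Nc2ccc([N+](=O)[O-])cc2)CCCCC1)c1ccccc1` gives 246 nM.

Compound 2 holds the lowest of the three numbers in this assay: a 4.6-fold lower number from compound 1 to compound 2 (0.67 log units; beyond the scatter) and a 6.2-fold higher number from compound 2 to compound 3 (0.79 log units; beyond the scatter) both lie beyond the scatter, while a 1.3-fold higher number from compound 1 to compound 3 (0.12 log units; within the scatter) does not.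

Compound 4 `O=C(OC1(C(=O)Nc2ccc([N+](=O)[O-])cc2)CCCCC1)C(O)c1ccccc1` has not been measured. It differs from compound 2 in one place: hydroxy(phenyl)methyl in place of 4-methoxyphenyl on a carbonyl carbon. Within the data shown here, only the step to compound 3 bears on this, since it also takes away the methoxy, and it was modest; the rest of the change has no measured counterpart. Compound 4 is therefore expected to give a higher number than compound 2, roughly a 5.5-fold higher number from compound 2 to compound 4 (0.74 log units; beyond the scatter). The estimate for compound 4 in this assay is 220 nM, with a range from 60 nM to 800 nM.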

Compound 4, half-maximal inhibitory concentration: 84.4 nM
The estimate for compound 4 lay 2.6-fold (0.42 log units) above the measured number, within the range that was stated.
By their numbers in this assay, from the lowest: compound 2; then compound 4; then compounds 1 and 3 (each within the scatter of the next).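

Replacing 4-methoxyphenyl with hydroxy(phenyl)methyl on the carbonyl carbon gives a 2.1-fold higher number from compound 2 to compound 4 (0.32 log units; beyond the scatter), so in this assay this position accepts a group with a hydrogen-bond donor while still falling short of compound 2. The same group improves on phenyl, with a 2.9-fold lower number from compound 3 to compound 4 (0.46 log units; beyond the scatter), and on 4-(trifluoromethyl)phenyl, with a 2.2-fold lower number from compound 1 to compound 4 (0.34 log units; beyond the scatter), so aromatic substituents are not the only route to a lower number here. No measurement on hand gives a cause for these steps. The compounds shown leave open what the hydroxy contributes on its own, and how an amine or a methoxy in its place would read.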